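Series notes: aryl swap on the amide-type ring nitrogen

The compounds below may be only part of what the source reports. "The series", "measured", "known", "first", "only" and "open" are said of these compounds alone.

Compound 1 `Cc1nc(-c2ccc(Cl)cc2)sc1C1SCC(=O)N1c1ccc(F)c(Cl)c1`, in a functional assay on the whole organism (strain Wistar albino) for inhibition, with Rattus norvegicus as the target, read by paw edema, with stated times of 1 h and 4 h, at a dose of 40 mg/kg by the oral route; a lower number here means less inhibition, a higher number more inhibition at the dose given (going by the name of the read-out): 65.1%
Compound 2 `Cc1nc(Cc2ccc(Cl)cc2)sc1C1SCC(=O)N1c1ccc(F)c(Cl)c1`, in this assay: 68.9%

Compound 2 stands with compound 1 inside the scatter, the step from one to the other being a number 3.8 percentage points higher from compound 1 to compound 2 (within the scatter). Compound 3 `Cc1ccc(N2C(=O)CSC2c2sc(Cc3ccc(Cl)cc3)nc2C)cc1` carries 4-methylphenyl in place of 3-chloro-4-fluorophenyl on an amide-type nitrogen in a ring. For the measured compounds named here, no measured step alters the group on the amide-type nitrogen in a ring; the only step measured, a number 3.8 percentage points higher from compound 1 to compound 2 (within the scatter), concerns the other aryl group. Nothing in these two numbers points in either direction, so the expected step of a number 3.9 percentage points lower from compound 2 to compound 3 (within the scatter) is none beyond the scatter. Compound 3 is therefore estimated at 65%, range 45% to 80%.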

Compound 3, a percentage reported as inhibition, in the whole organism at one dose (the size of the read-out at that dose, not a potency): 81.3%
Compound 3: the middle estimate sits 16.3 percentage points below what was measured; measured number above the stated range.
By their numbers in this assay, from the lowest: compounds 1 and 2 (each within the scatter of the next); then compound 3.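

The group on the amide-type nitrogen in a ring is a place where a single change moves the read-out beyond the scatter: in this assay, 4-methylphenyl in place of 3-chloro-4-fluorophenyl gives a number 12.4 percentage points higher from compound 2 to compound 3 (beyond the scatter). The step at the other aryl group, a number 3.8 percentage points higher from compound 1 to compound 2 (within the scatter), stayed within the scatter. No measurement at hand bears on why this change raises the number.

Open, going by these compounds, is whether the methyl group or the loss of the chlorine and fluorine carries the step, and how phenyl or 4-methoxyphenyl on this nitrogen would read. Also open, on these data alone, is whether 4-methylphenyl gives a similar step when 4-chlorophenyl replaces 4-chlorobenzyl.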